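Compound 4 from compound 1: expected cytotoxicity

The compounds below may be only part of what the source reports. "The series", "measured", "known", "first", "only" and "open" are said of these compounds alone.

Compound 1 `CC1CC=C(C(=O)N(c2cc(C#CC(C)(C)C)sc2C(=O)O)C(C)C)CC1` was run in an ADME assay on MT4 cells (Homo sapiens) for cytotoxicity, with a stated time of 5 days; on this read-out higher numbers stand for lower toxicity in this test and lower numbers for higher toxicity in this test; there compound 1 gives > 20000 nM, which is a limit of the test and not a number. Compound 2 `CC(C)(C)C#Cc1cc(N(C(=O)[C@H]2CC[C@H](C)CC2)[C@H]2CC[C@@](O)(CO[C@H]3CCOC3)CC2)c(C(=O)O)s1` gives a limit as well in this assay, > 20000 nM. Compound 3 `CC(C)(C#Cc1cc(N(C(=O)[C@H]2CC[C@H](C)CC2)[C@H]2CC[C@H](Oc3ccc(=O)[nH]n3)CC2)c(C(=O)O)s1)C(F)(F)F` likewise gives a limit in this assay, > 20000 nM. Compound 1 therefore stands where every value shown stands, at the limit of > 20000 nM in this assay, at which 3 of the 3 values shown sit. Among the compounds with values here, no two of these three compounds differ in a single place, so no measured step exists. Compound 4 `CC(C)N(c1cc(C#CC(C)(C)C)sc1C(=O)O)C(=O)[C@H]1CC[C@H](C)CC1` differs from compound 1 by 4-methylcyclohexyl in place of 4-methylcyclohex-1-en-1-yl on a carbonyl carbon. With nothing in the shown values that separates compounds, the step of a number no higher from compound 1 to compound 4 (the limit leaves the size open) is expected to be none beyond the usual scatter. Compound 4 is estimated at 20000 nM, between 10000 nM and 60000 nM, most likely reported again only as a limit.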

Compound 4, half-maximal cytotoxic concentration: > 20000 nM
Compound 4: only a limit was reported; the forecaster's own chance of this, stated with the estimate: 85%; the middle value sits exactly at the limit.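

Compound 1 and compound 4 both sit at a limit of the test, not at a number, so no step can be read between them. In this assay the compounds shown leave open which structural change, if any, would give a readable value: the limit of > 20000 nM in this assay, at which 4 of the 4 values shown sit.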